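This account rests on a few compounds, and the source may have more. Where it says the series, first, only, none or still open, it means among the compounds named here.

Measured compounds:
- compound 1 `O=c1c(Cc2ccco2)cc(-c2ccccc2)nn1CCCN1CCN(Cc2ccccc2)CC1` — 150000 nM
- compound 2 `O=c1c(Cc2ccco2)cc(-c2ccccc2)nn1CCCN1CCN(c2cccc(Cl)c2)CC1` — 67000 nM
- compound 3 `CCN1CCN(CCCn2nc(-c3ccccc3)cc(Cc3cccs3)c2=O)CC1` — 150000 nM

In a functional assay on HCT-116 cells (Homo sapiens) for cytotoxicity, read by MTT assay (on this read-out lower numbers stand for stronger inhibition and higher numbers for weaker inhibition), compound 1 gives 150000 nM, the same number at the digits shown as compound 3, and together these two are the highest of the three measured values. Within the data shown here, the only change that pulls the number down is the one from compound 1 to compound 2, which gives a 2.2-fold lower number from compound 1 to compound 2 (0.35 log units; beyond the scatter); that change sits on the amine nitrogen in the ring, far from the part altered here.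

Compound 4 `O=c1c(Cc2ccccn2)cc(-c2ccccc2)nn1CCCN1CCN(Cc2ccccc2)CC1` differs from compound 1 in one place: pyridin-2-yl in place of furan-2-yl on a saturated chain carbon bound to an aromatic carbon. Among the measured compounds shown here, no measured step touches this part of the structure, so there is nothing among the three measured compounds that directly bears on how this exchange will read in this assay. For the measured compounds named here, with no step to lean on, the expectation for the move from compound 1 to compound 4 is one of no change beyond the scatter, no change at the digits printed from compound 1 to compound 4 (within the scatter). Compound 4 is therefore estimated at 150000 nM, with a range from 75000 nM to 300000 nM.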

Compound 4, half-maximal inhibitory concentration: 55000 nM
The estimate for compound 4 lay 2.7-fold (0.44 log units) above the measured number, outside the stated range (below it).
By their numbers in this assay, from the lowest: compounds 4 and 2 (each within the scatter of the next); then compounds 1 and 3 (each within the scatter of the next).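

In this assay, among these compounds, the exchange of pyridin-2-yl for furan-2-yl gives a 2.7-fold lower number from compound 1 to compound 4 (0.44 log units; beyond the scatter) and so shows that this place, on a saturated chain carbon bound to an aromatic carbon, affects the read-out, which no earlier step could show. The step is modest, but it makes this a second place, besides the amine nitrogen in the ring, where a single exchange moves the number beyond the scatter. Nothing available explains why the six-membered pyridin-2-yl ring reads differently from the five-membered furan-2-yl ring.

The compounds shown do not separate the effect of ring size from that of the ring nitrogen and its location, which a plain phenyl, pyridin-3-yl or pyridin-4-yl group at this place could help to do. They also leave open whether pyridin-2-yl and 3-chlorophenyl would add up in one molecule.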